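Shortening the alkyne chain on compound 1

A few compounds are considered here, and "the series" means these few. Any claim that something is new, unique, unknown or untested is made for them only; others in the source may bear on it.

Compound 1, `CCCC#Cc1cn([C@@H]2O[C@H](CO)[C@@H](O)[C@H](O)[C@H]2O)c(=O)nc1N`, in a functional assay on CCRF-CEM cells (Homo sapiens) for cytotoxicity, with a stated time of 72 h (a lower number here means a stronger inhibitor, a higher number a weaker inhibitor), gives > 250000 nM, which is a limit of the assay rather than a number. Compound 2, `O=c1nc(O)c(C#Cc2ccccc2)cn1[C@@H]1O[C@H](CO)[C@@H](O)[C@H](O)[C@H]1O`, gives 5200 nM in this assay. Compound 3, `CC(C)(C)c1ccc(C#Cc2cn([C@@H]3O[C@H](CO)[C@@H](O)[C@H](O)[C@H]3O)c(=O)nc2O)cc1`, gives > 250000 nM in this assay, again a limit and not a number.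

Compound 1 therefore stands at the limit, where two of the three values shown sit (the limit of > 250000 nM in this assay, at which 2 of the 3 values shown sit). Compound 4, `C#Cc1cn([C@@H]2O[C@H](CO)[C@@H](O)[C@H](O)[C@H]2O)c(=O)nc1N`, differs from compound 1 by hydrogen in place of propyl on a triple-bonded carbon. Among the measured compounds shown here, the only measured step, an at least 48-fold higher number from compound 2 to compound 3 (1.68 log units; beyond the scatter), shows that adding a bulky group at the far end of the alkyne can weaken activity strongly; it runs in the opposite direction to the change made here, which removes bulk, and it sits on a different core. It gives no direct guide to whether trimming propyl to hydrogen helps. Compound 4 is expected to stay near the limit, with an estimated step of an at least 1.2-fold lower number from compound 1 to compound 4 (0.09 log units; that floor lies within the scatter). The expected value for compound 4 in this assay is 200000 nM, within a range from 20000 nM to 1000000 nM.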

Compound 4, half-maximal inhibitory concentration: > 250000 nM
Compound 4: only a limit was reported (the forecaster's own chance of this, stated with the estimate: 60%); at least 1.2-fold (0.09 log units) between middle value and limit.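

In this assay compound 4 gives > 250000 nM, a limit and not a number. Among the compounds shown here, compound 1 also sits at a limit, so no step from compound 1 to compound 4 can be read. The compounds shown leave open whether hydrogen in place of propyl changes cytotoxicity at all.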